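Replacing the five-membered ring end: compound 3 to compound 4

A few compounds are considered here, and "the series" means these few. Any claim that something is new, unique, unknown or untested is made for them only; others in the source may bear on it.

Measured in a functional assay on MCF7 cells (Homo sapiens) for antiproliferative activity, read by MTT assay, with a stated time of 72 h; a lower number here means a stronger inhibitor, a higher number a weaker inhibitor:
- compound 1 `CCCSc1nc(N/N=C/c2cccnc2)c2nnn(Cc3ccccc3)c2n1`: 58700 nM
- compound 2 `CCCSc1nc(N/N=C(\C)c2ccc(O)cc2)c2nnn(Cc3ccccc3)c2n1`: 21600 nM
- compound 3 `CCCSc1nc(N/N=C/c2cccs2)c2nnn(Cc3ccccc3)c2n1`: > 64000 nM (a limit)

Compound 3 stands at > 64000 nM in this assay, which is a limit of the assay and not a number. Compound 4 `CCCSc1nc(N/N=C(\C)c2ccc(Br)cc2)c2nnn(Cc3ccccc3)c2n1` differs from it by a group of 10 heavy atoms (8 carbon, 1 nitrogen, 1 bromine; one six-membered aromatic ring of carbon only) in place of a group of 7 heavy atoms (5 carbon, 1 nitrogen, 1 sulfur; one five-membered aromatic ring with 1 hetero atom), on a nitrogen on an aromatic ring. The closest measured precedent is an at least 2.9-fold higher number from compound 2 to compound 3 (0.47 log units; beyond the scatter), where the same two ring types traded places in the opposite sense. The measured step of a 2.7-fold lower number from compound 1 to compound 2 (0.43 log units; beyond the scatter) also brought in one six-membered aromatic ring of carbon only and led to a lower number. The step of an at least 1.0-fold higher number from compound 1 to compound 3 (0.03 log units; that floor lies within the scatter) has a floor within the scatter and adds little. The bromine-bearing group itself has no measured precedent among these compounds. Compound 2, at 21600 nM, therefore sets the expected level. The expected change in this assay is a modest move to a lower number, estimated as an at least 3.2-fold lower number from compound 3 to compound 4 (0.50 log units; beyond the scatter). For compound 4 the estimated value is 20000 nM, with an expected range of 7000 nM to 55000 nM.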

Compound 4, half-maximal inhibitory concentration: 13000 nM
Estimate against measurement, compound 4: 1.5-fold (0.19 log units) above, and the stated range covers the measured number.
By their numbers in this assay, from the lowest: compounds 4 and 2 (each within the scatter of the next); then compound 1. At a limit, above all of these: compound 3.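

In this assay, bromo stands in place of hydroxy on the aromatic carbon with no change beyond the scatter: a 1.7-fold lower number from compound 2 to compound 4 (0.22 log units; within the scatter). The level seen in compound 2 therefore does not depend on the hydroxy group alone, and the group with the six-membered aromatic ring of carbon only also holds its advantage over the pyridin-3-yl compound with bromo on it: a 4.5-fold lower number from compound 1 to compound 4 (0.65 log units; beyond the scatter). Compound 3 remains a limit of the assay, so the step of an at least 4.9-fold lower number from compound 3 to compound 4 (0.69 log units; beyond the scatter) gives only a floor: the limit of > 64000 nM in this assay, at which 1 of the 4 values shown sits.

Going by these compounds, whether an amine or a carboxylic acid in place of bromo on the aromatic carbon would hold this level stays open. On these data alone, the ring change and the methyl group carried by compound 2 and compound 4 enter together in every step from compound 1 or compound 3, so their separate contributions also stay open.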